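Chain end swap: compound 3 to compound 4

A few compounds are considered here, and "the series" means these few. Any claim that something is new, unique, unknown or untested is made for them only; others in the source may bear on it.

Measured so far in an ADME assay on microsomes from liver (Mus musculus) for metabolic stability, tested at 5 uM; a higher number here means that the compound lasts longer, a lower number that the compound disappears faster:
- compound 1 `CCCCCCCCNc1ccc(C(=O)O)cc1S(=O)(=O)NC`: 0.2 h
- compound 2 `CCCCCCNc1ccc(C(=O)O)cc1S(=O)(=O)N(C)C`: 0.283 h
- compound 3 `CN(C)S(=O)(=O)c1cc(C(=O)O)ccc1NCCC(C)(C)C`: > 1 h

For compound 3 the reading of > 1 h is a limit of the assay and not a number.

Compound 4 `CN(C)S(=O)(=O)c1cc(C(=O)O)ccc1NCCCCCC(F)(F)F` carries 4,4,4-trifluorobutyl in place of tert-butyl on a saturated chain carbon, two bonds along the chain from a nitrogen on an aromatic ring.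

Going by the values given here, the one measured step that bears on this is an at least 3.5-fold higher number from compound 2 to compound 3 (0.54 log units; beyond the scatter), where tert-butyl took the place of butyl. Here tert-butyl leaves again, and no measured step shows what 4,4,4-trifluorobutyl does in place of butyl. The expectation in this assay is therefore a downward move, leaning towards compound 2, which reads 0.283 h, though not necessarily all the way back. The expected change is an at least 2.0-fold lower number from compound 3 to compound 4 (0.30 log units; that floor lies within the scatter), and its size is uncertain since the starting point is only a limit. Compound 4 is estimated at 0.5 h, with an expected range from 0.2 h to 1.2 h.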

Compound 4, half-life: > 1 h
Compound 4: no number, only a limit; the forecaster's own chance of this, stated with the estimate: 20%; middle value at least 2.0-fold (0.30 log units) away from the limit.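

In this assay, trifluoromethyl in place of methyl on a saturated chain carbon, five bonds along the chain from a nitrogen on an aromatic ring, gives an at least 3.5-fold higher number from compound 2 to compound 4 (0.54 log units; beyond the scatter). Going by these compounds alone, a branched tert-butyl chain end is therefore not the only change at this position that moves the series clear of compound 2, as an unbranched chain ending in trifluoromethyl also does so. The step between compound 3 and compound 4 cannot be read, and the order of tert-butyl and 4,4,4-trifluorobutyl at this position stays unresolved, because both compounds sit at the same limit: the limit of > 1 h in this assay, at which 2 of the 4 values shown sit.

Going by these compounds, how far compound 3 and compound 4 lie beyond that limit remains open, so a reading over a longer time course would be needed to separate them. Also open, on these data alone, is which part of the change in compound 4 carries the step, which a difluoromethyl or monofluoromethyl chain end on the same chain, or a shorter chain ending in trifluoromethyl, would help to define.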